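Methoxy to methylsulfanyl on the shared core

The source may report more compounds than this note shows. Statements on the series, on what has been measured and on what is new or still open speak of the compounds shown alone.

Of the compounds shown here, three built on one shared core have been measured in an ADME assay on BJ cells (Homo sapiens), read by MTT assay, with a stated time of 72 h; a higher number here means a weaker inhibitor, a lower number a stronger inhibitor. Compound 1 `COc1ncnc2c1c(-c1ccoc1)cn2[C@@H]1O[C@H](CO)[C@@H](O)[C@H]1O` gives 28800 nM. Compound 2 `COc1ncnc2c1c(-c1cccs1)cn2[C@@H]1O[C@H](CO)[C@@H](O)[C@H]1O` gives 62800 nM, and compound 3 `COc1nc(N)nc2c1c(-c1cccs1)cn2[C@@H]1O[C@H](CO)[C@@H](O)[C@H]1O` gives 99900 nM. Among the three numbers, compound 2 holds the second highest: its nearest neighbour is compound 3, through a 1.6-fold higher number from compound 2 to compound 3 (0.20 log units; within the scatter), while compound 1 lies furthest away, through a 2.2-fold higher number from compound 1 to compound 2 (0.34 log units; beyond the scatter).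

Compound 4 `CSc1ncnc2c1c(-c1cccs1)cn2[C@@H]1O[C@H](CO)[C@@H](O)[C@H]1O` differs from compound 2 in a single place: methylsulfanyl in place of methoxy on an aromatic carbon. Neither measured step concerns this kind of change; one exchanges thiophen-2-yl for furan-3-yl, the other puts amino in place of hydrogen, and both were modest at most. No direct guidance exists for the swap of methoxy for methylsulfanyl, and the two groups match in what is counted. A step no larger than the scatter is therefore expected in this assay, in either direction. Compound 4 is estimated at 60000 nM, within 25000 nM to 150000 nM, which means an expected step of a 1.0-fold lower number from compound 2 to compound 4 (0.02 log units; within the scatter).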

Compound 4, half-maximal inhibitory concentration: 96900 nM
Compound 4: middle estimate off by 1.6-fold (0.21 log units), on the low side; low and high end bracket the measured number.
By their numbers in this assay, from the lowest: compound 1; then compounds 2, 4 and 3 (each within the scatter of the next).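

On an aromatic carbon next to the ring nitrogen, methylsulfanyl in place of methoxy gives a 1.5-fold higher number from compound 2 to compound 4 (0.19 log units; within the scatter) in this assay and so stays inside the usual scatter. Within the data shown here, this is the first reading at this position, since the earlier steps changed the thiophen-2-yl or furan-3-yl group and added amino elsewhere on the shared core. For this one pair, then, a sulfur can take the place of the oxygen in this small group without a change that can be told from the scatter, and no supporting measurement bears on this result.

On these data alone, it remains open whether a larger or different group at this position, such as ethoxy, a longer chain or dimethylamino, would also stay within the scatter. As far as these compounds go, whether the same exchange behaves alike with furan-3-yl in place of thiophen-2-yl also remains open.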